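Thiophene in Place of Methoxyphenyl: One Step Forward

A few compounds are considered here, and "the series" means these few. Any claim that something is new, unique, unknown or untested is made for them only; others in the source may bear on it.

Compound 1 `c1ccc(-c2cn3ccnc3c(-c3ccc4ncn(C5CCCCC5)c4c3)n2)cc1`: 26.1%
Compound 2 `COc1ccccc1-c1cn2ccnc2c(-c2ccc3ncn(C4CCCCC4)c3c2)n1`: 13.9%

Among the compounds with values here, in a functional assay on A498 cells (Homo sapiens) for inhibition, read by sulforhodamine B assay, with a stated time of 48 h, tested at 10 uM (a lower number here means less inhibition, a higher number more inhibition at the concentration tested (going by the name of the read-out)), compound 2 stands lowest of the two measured compounds, below compound 1 by the single measured step of a number 12.2 percentage points lower from compound 1 to compound 2 (beyond the scatter), and that step is the only one bearing on what follows. Compound 3 `c1csc(-c2cn3ccnc3c(-c3ccc4ncn(C5CCCCC5)c4c3)n2)c1` differs from compound 2 in thiophen-2-yl in place of 2-methoxyphenyl on an aromatic carbon. The change takes the methoxy away with the phenyl, so the measured step is expected to run partly in reverse, a modest rise of a number 8.1 percentage points higher from compound 2 to compound 3 (within the scatter). Compound 3 is therefore expected to give 22% in this assay, within a range from 8% to 38%.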

Compound 3, a percentage reported as inhibition, at one concentration (the size of the read-out at that concentration, not a potency): 25%
Compound 3: the middle estimate sits 3 percentage points below what was measured, within the range that was stated.
By their numbers in this assay, from the lowest: compound 2; then compounds 3 and 1 (each within the scatter of the next).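

Thiophen-2-yl in place of 2-methoxyphenyl gives a number 11.1 percentage points higher from compound 2 to compound 3 (beyond the scatter), so this position can regain the ground lost with the methoxy-bearing ring. Thiophen-2-yl in place of phenyl gives a number 1.1 percentage points lower from compound 1 to compound 3 (within the scatter), which shows that a five-membered aromatic ring with a sulfur can stand here with no change beyond the scatter, leaving compound 2 alone apart from the other two. Nothing measured explains these differences. Going by these compounds, whether an amine or a carboxylic acid on the thiophene would shift the number remains open. So does whether a pyridine ring at this place would stand level with phenyl and thiophen-2-yl.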